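The source may hold more compounds than are shown below. What is called first, only, known or untested is meant among the compounds shown, and "the series" means these compounds.

Measured compounds in a functional assay, with a stated time of 150 min; on this read-out lower numbers stand for stronger inhibition and higher numbers for weaker inhibition:
- compound 1, `COc1ccc(-c2nc(SC)n(C)c(=O)c2C#N)cc1`: 73 ug/mL
- compound 2, `CCOC(=O)c1cnn(-c2nc(-c3ccccc3F)c(C#N)c(=O)n2C)c1N`: 87 ug/mL
- compound 3, `CSc1nc(-c2ccco2)c(C#N)c(=O)n1C`: 108 ug/mL

All three compounds share the same core and were tested in this assay. Compound 2 gives the second highest of the three numbers; its nearest neighbour is compound 1 and its furthest is compound 3, and both gaps lie within the usual scatter of repeated measurements, so no order can be read among them.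

Compound 4, `CCOC(=O)c1cnn(-c2nc(-c3ccc(N(C)C)cc3)c(C#N)c(=O)n2C)c1N`, has not yet been tested. It differs from compound 2 in one place: 4-(dimethylamino)phenyl in place of 2-fluorophenyl on an aromatic carbon. Going by the values given here, nothing among the measured compounds shows what this kind of exchange does in this assay, as no pair differs in exactly one spot, so there is no measured step to lean on.

The three measured values cluster closely, and compound 2 sits among them at 87 ug/mL. Compound 4 is therefore expected to land near the same region, with a step of a 1.1-fold lower number from compound 2 to compound 4 (0.04 log units; within the scatter) that is estimated to stay within the scatter. The estimate for compound 4 is 80 ug/mL, in a range from 35 ug/mL to 200 ug/mL.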

Compound 4, half-maximal inhibitory concentration: 115 ug/mL
Estimate against measurement, compound 4: 1.4-fold (0.16 log units) below; the range from low to high includes it.
By their numbers in this assay, from the lowest: compounds 1, 2, 3 and 4 (each within the scatter of the next).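

In this assay, going by these compounds alone, the exchange of 2-fluorophenyl for 4-(dimethylamino)phenyl on this aromatic carbon gives a 1.3-fold higher number from compound 2 to compound 4 (0.12 log units; within the scatter), the first comparison here of two compounds that differ in one place. This position, ortho to a cyano group, therefore carries the larger 4-(dimethylamino)phenyl with a read-out that cannot be told apart from that of the 2-fluorophenyl compound. Nothing measured alongside these compounds bears on why the two read alike.

The fluorine and the dimethylamino group differ in one step. A plain phenyl ring would be needed to look at each of them alone. On these data alone, whether a carboxylic acid or a morpholine on the phenyl ring at this position would move the number beyond the scatter also remains open.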